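A Ring-Bearing Side Group on a Shared Core

This account rests on a few compounds, and the source may have more. Where it says the series, first, only, none or still open, it means among the compounds named here.

Two compounds with a shared core have numbers in a functional assay on PC-3 cells (Homo sapiens) for inhibition, read by MTT assay, with a stated time of 48 h, tested at 10 uM; on this read-out higher numbers stand for more inhibition of growth at the one concentration tested and lower numbers for less inhibition of growth. Compound 1 (`Cc1cc(=O)c2c(O)cc(O)c([C@H]3CCN(C)C[C@H]3OC(=O)c3ccco3)c2o1`) gives 23%, and compound 2 (`Cc1cc(=O)c2c(O)c(CN(C)CC(=O)O)c(O)c([C@H]3CCN(C)C[C@H]3O)c2o1`) gives 20%. These two values lie within the scatter of each other, so compound 2 stands level with compound 1 on the numbers available. Compound 3 (`Cc1cc(=O)c2c(O)c(CN3CCCC3C(=O)O)c(O)c([C@H]3CCN(C)C[C@H]3O)c2o1`) departs from compound 2 at one place: 2-carboxypyrrolidin-1-yl in place of (carboxymethyl)(methyl)amino on a saturated chain carbon bound to an aromatic carbon. It carries 2-carboxypyrrolidin-1-yl in place of (carboxymethyl)(methyl)amino on a saturated chain carbon bound to an aromatic carbon. Within the data shown here, no measured pair shows what such a change does, so no step beyond the scatter is expected in this assay, and compound 2 at 20% serves as the starting point. The estimated change is a number 1 percentage points higher from compound 2 to compound 3 (within the scatter). Compound 3 is expected at 21%, with an estimated range of 7% to 38%.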

Compound 3, percent growth inhibition at one concentration: 0%
Compound 3: the middle estimate sits 21 percentage points above what was measured; measured number below the stated range.
By their numbers in this assay, from the lowest: compound 3; then compounds 2 and 1 (each within the scatter of the next).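

Among these compounds, at the saturated chain carbon bound to an aromatic carbon, 2-carboxypyrrolidin-1-yl in place of (carboxymethyl)(methyl)amino gives the first reading of a single change in this assay, with a number 20 percentage points lower from compound 2 to compound 3 (beyond the scatter) as the step. The result shows that the number in this assay responds to what stands at this place, even though the group that enters has the same counts of hydrogen-bond donors and acceptors as the group that leaves. No measurement in hand explains this step.

The compounds shown do not separate the five-membered non-aromatic ring from the carboxylic acid it carries. Plain pyrrolidin-1-yl, without the carboxylic acid, or a piperidine ring bearing a carboxylic acid at the same place would each test a different part of this change.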